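Compound 1 to compound 3: losing the benzyl group

This account rests on a few compounds, and the source may have more. Where it says the series, first, only, none or still open, it means among the compounds named here.

Among the compounds with values here, in an ADME assay on CHO cells (Cricetulus griseus) for inhibition, read by MTT assay (a lower number here means a stronger inhibitor, a higher number a weaker inhibitor), compound 1 (`CC(C)(C)NCc1cc(Cl)cc(Nc2nc3ccccc3n2Cc2ccc(C(F)(F)F)cc2)c1O`) gives 36300 nM, the only true number so far. Compound 2 (`CCN(CC)Cc1cc(Cl)cc(Nc2nc3ccccc3n2Cc2ccc(C(F)(F)F)cc2)c1O`) gives > 50000 nM, which is a limit of the assay. Within the data shown here, the one measured step is an at least 1.3-fold higher number from compound 1 to compound 2 (0.13 log units; that floor lies within the scatter). It concerns the amine on the chain, not the aromatic nitrogen, so it bears only weakly on the change considered here.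

Compound 3 (`CC(C)(C)NCc1cc(Cl)cc(Nc2nc3ccccc3[nH]2)c1O`) has hydrogen in place of 4-(trifluoromethyl)benzyl on an aromatic nitrogen. Among the measured compounds shown here, no measured step covers a change at that place, so neither size nor direction is established, and the range must stay wide. The step expected in this assay is a 1.1-fold higher number from compound 1 to compound 3 (0.04 log units; within the scatter), none beyond the scatter. Compound 3 could also be reported only as a limit. For compound 3 the estimated value is 40000 nM, with an expected range of 15000 nM to 80000 nM.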

Compound 3, half-maximal inhibitory concentration: > 50000 nM
Compound 3: a limit, no number; the forecaster's own chance of this, stated with the estimate: 45%; middle value at least 1.2-fold (0.09 log units) away from the limit.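

Within the data shown here, compound 3 gives the first reading at the aromatic nitrogen that carries 4-(trifluoromethyl)benzyl in compound 1, as the earlier step concerned only the amine on the chain. In this assay, hydrogen in place of that group gives an at least 1.3-fold higher number from compound 1 to compound 3 (0.13 log units; that floor lies within the scatter) and so fixes a floor rather than a size, with no sign that the benzyl group can be lost in favour of a lower number. The step cannot be sized further because the reading stops at a limit of the assay: the limit of > 50000 nM in this assay, at which 2 of the 3 values shown sit.

On these data alone, how far the true value of compound 3 lies from that limit stays open. So does how a plain benzyl, a methyl or a 4-chlorobenzyl on the same aromatic nitrogen would read, which would show whether anything at this place moves the number.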